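The compounds below may be only part of what the source reports. "The series", "measured", "known", "first", "only" and "open" are said of these compounds alone.

Measured in an assay on isolated protein for inhibition of Amine oxidase [flavin-containing] A (Homo sapiens), read by fluorescence, with stated times of 15 min and 20 min; a lower number here means a stronger inhibitor, a higher number a weaker inhibitor:
compound 1 `Cc1ccc(CN2CCC(CCNC(=O)/C=C/c3cc(C(C)(C)C)c(O)c(C(C)(C)C)c3)CC2)cc1`: 70100 nM
compound 2 `CC(C)(C)c1cc(/C=C/C(=O)NCCC2CCN(Cc3cccc(Cl)c3)CC2)cc(C(C)(C)C)c1O`: 65100 nM

Compound 2 and compound 1 lie within the scatter of one another on these two numbers, so neither is put ahead of the other. Among the measured compounds shown here, the one measured step, a 1.1-fold lower number from compound 1 to compound 2 (0.03 log units; within the scatter), swaps the aromatic ring on the saturated chain carbon bound to an amine nitrogen in a ring and shows nothing beyond the scatter. Compound 3 `CC(C)(C)c1cc(/C=C/C(=O)NCCC2CCN(Cc3ccc(C#N)cc3)CC2)cc(C(C)(C)C)c1O` differs from compound 2 in that same place: 4-cyanophenyl in place of 3-chlorophenyl on a saturated chain carbon bound to an amine nitrogen in a ring. For the measured compounds named here, the only measured change bearing on this is the step from compound 1 to compound 2, which was flat, so for compound 3 no step beyond the scatter is expected in this assay in either direction; the expected step is a 1.0-fold lower number from compound 2 to compound 3 (0.00 log units; within the scatter). The estimate for compound 3 is 65000 nM, with a range from 25000 nM to 170000 nM. This rests on a single comparison across two aromatic rings only.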

Compound 3, half-maximal inhibitory concentration: 78200 nM
Estimate against measurement, compound 3: 1.2-fold (0.08 log units) below; the measured number falls inside the stated range.
By their numbers in this assay, from the lowest: compounds 2, 1 and 3 (each within the scatter of the next).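

In this assay, the place on a saturated chain carbon bound to an amine nitrogen in a ring now has a third aromatic ring, and 4-cyanophenyl, which carries a hydrogen-bond acceptor and a triple bond that 3-chlorophenyl lacks, gives a 1.2-fold higher number from compound 2 to compound 3 (0.08 log units; within the scatter). Cyano in place of methyl on an aromatic carbon likewise gives a 1.1-fold higher number from compound 1 to compound 3 (0.05 log units; within the scatter), so no substituent change among compounds 1, 2 and 3 gives a step beyond the scatter. No measurement shown here offers an explanation for this flat result.

Still open, going by these compounds, is whether a carboxylic acid or an amine on this aromatic ring, or a pyridine in place of it, would give a step beyond the scatter. The same question stands for a longer chain in the linker of the shared core.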